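A few compounds are considered here, and "the series" means these few. Any claim that something is new, unique, unknown or untested is made for them only; others in the source may bear on it.

Measured in a functional assay on DU-145 cells (Homo sapiens) for inhibition, read by trypan blue exclusion, with a stated time of 96 h (a higher number here means a weaker inhibitor of growth, a lower number a stronger inhibitor of growth), so far:
- Compound 1 `O=C(/C(=C\c1ccc(Cl)cc1Cl)S(=O)(=O)c1ccc(Br)cc1)c1ccc(Cl)cc1` gives 50000 nM
- Compound 2 `O=C(/C(=C\c1ccc(Br)c(O)c1)S(=O)(=O)c1ccc(Br)cc1)c1ccc(Br)cc1` gives 50000 nM
- Compound 3 `O=C(/C(=C\c1ccc(Cl)cc1Cl)S(=O)(=O)c1ccc(Br)cc1)c1ccc(Br)cc1` gives 10000 nM

Compound 3 has the lowest number of the three, and compound 1 and compound 2 share the same higher value. Compound 4 `COc1ccc(/C=C(\C(=O)c2ccc(Br)cc2)S(=O)(=O)c2ccc(Br)cc2)c(OC)c1` differs from compound 3 in one place, with 2,4-dimethoxyphenyl in place of 2,4-dichlorophenyl on a double-bonded chain carbon bound to a double-bonded chain carbon as the counted change: 2,4-dimethoxyphenyl in place of 2,4-dichlorophenyl on a double-bonded chain carbon bound to a double-bonded chain carbon.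

At this same place the data show a 5.0-fold lower number from compound 2 to compound 3 (0.70 log units; beyond the scatter) as a modest step. The other measured step, a 5.0-fold lower number from compound 1 to compound 3 (0.70 log units; beyond the scatter), lies elsewhere and only indicates how large a single change has been in this small set. Neither step tests the entering group, so the direction is uncertain. Both neighbours of compound 3 have higher numbers, so a modest step upward in this assay is expected, no larger than those seen. The expected step is a 2.0-fold higher number from compound 3 to compound 4 (0.30 log units; within the scatter) as a rough guide. Compound 4 is estimated at 20000 nM with an expected range from 6000 nM to 60000 nM in this measure.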

Compound 4, concentration for 50% growth inhibition: 8000 nM
For compound 4 the middle estimate is 2.5-fold (0.40 log units) above the measured one, within the range that was stated.
By their numbers in this assay, from the lowest: compounds 4 and 3 (each within the scatter of the next); then compounds 1 and 2 (each within the scatter of the next).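

In this assay, the step of a 1.3-fold lower number from compound 3 to compound 4 (0.10 log units; within the scatter) shows that 2,4-dimethoxyphenyl and 2,4-dichlorophenyl cannot be told apart at this place, even though the hydrogen-bond acceptors counted in the entering group are absent from the group that leaves. The step of a 6.3-fold lower number from compound 2 to compound 4 (0.80 log units; beyond the scatter) is beyond the scatter, so compound 2, with its 4-bromo-3-hydroxyphenyl, now stands apart from both compound 3 and compound 4 on a double-bonded chain carbon bound to a double-bonded chain carbon. No measurement given here offers a reason for either reading.

From the compounds shown here alone, it remains open whether an amine or a carboxylic acid on this aromatic ring would keep the number at this level. Going by these compounds, it is also open whether 2,4-dimethoxyphenyl would read the same with the chloro found in compound 1 in place of the bromo.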